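Removing a Methyl from an Aryl Ether in Cytotoxicity Testing

This account rests on a few compounds, and the source may have more. Where it says the series, first, only, none or still open, it means among the compounds named here.

Compound 1 `COc1cc(C)cc(-c2nn(CC#N)cc2-c2ccc(-c3cccc(C(C)=O)c3)nc2)c1`: 16%
Compound 2 `Cc1cc(O)cc(-c2nn(CC#N)cc2-c2ccnc(-c3ccc(Oc4ccccc4)cc3)c2)c1`: 60%
Compound 3 `COc1cc(C)cc(-c2nn(CC#N)cc2-c2ccnc(-c3ccc(N(C)C)cc3)c2)c1`: 5%

These three compounds were tested in a functional assay on HOP-62 cells (Homo sapiens) for cytotoxicity, read by sulforhodamine B assay, with a stated time of 48 h, tested at 1 uM; a higher number here means a weaker effect of the compound at the concentration tested, a lower number a stronger effect. Compound 3 gives the lowest number of the three, and therefore the strongest effect: the gap to compound 1 is beyond the usual scatter, and the gap to compound 2 is far beyond it. Compound 2, which carries a hydroxy group where compound 3 carries a methoxy group but also differs elsewhere, shows a much weaker effect than compound 3; the two values alone cannot say which change matters.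

The unmeasured compound 4 `Cc1cc(O)cc(-c2nn(CC#N)cc2-c2ccnc(-c3ccc(N(C)C)cc3)c2)c1` keeps everything of compound 3 except one change: hydrogen in place of methyl on an oxygen on an aromatic ring. Among the measured compounds shown here, no measured pair isolates this change, so the expectation rests on the values of compounds 2 and 3 only. Some loss of effect is expected, with the step from compound 3 to compound 4 estimated at a number 15 percentage points higher from compound 3 to compound 4 (beyond the scatter). Compound 4 is therefore expected to give about 20% in this assay, within a range from 3% to 55%.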

Compound 4, a percentage reported as activity, at one concentration (the size of the read-out at that concentration, not a potency): 13%
For compound 4 the middle estimate is 7 percentage points above the measured one; the measured number falls inside the stated range.
By their numbers in this assay, from the lowest: compounds 3, 4 and 1 (each within the scatter of the next, the first and the last beyond it); then compound 2.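

In this assay, the methoxy to hydroxy change on the 3-methoxy-5-methylphenyl group gives a number 8 percentage points higher from compound 3 to compound 4 (within the scatter), so with dimethylamino in place, the methyl on this oxygen can be exchanged for hydrogen without a difference that stands clear of the scatter. With the hydroxy group held fixed, dimethylamino in place of phenoxy gives a number 47 percentage points lower from compound 2 to compound 4 (beyond the scatter), which shows that this second site has a large effect on the read-out. Nothing available explains either step.

On these data alone, only hydrogen and methyl are compared on this oxygen, so the outcome with an ethyl chain or an acetyl group there remains open, as does an amine replacing the hydroxy group. As far as these compounds go, whether exchanging methyl for hydrogen gives a similarly small step with phenoxy in place of dimethylamino also remains open.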